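Sulfonate aryl exchange: from compound 2 to compound 4

The compounds below may be only part of what the source reports. "The series", "measured", "known", "first", "only" and "open" are said of these compounds alone.

Measured so far:
compound 1 `N#Cc1cccc(S(=O)(=O)Oc2ccc(-c3cncn3C3CCN(C(=O)c4ccc(Cl)c(C(F)(F)F)c4)CC3)cc2)c1` gives 73 nM
compound 2 `CS(=O)(=O)c1ccc(C(=O)N2CCC(n3cncc3-c3ccc(OS(=O)(=O)c4cccc5cnccc45)cc3)CC2)cc1` gives 25 nM
compound 3 `CC(C)(O)c1ccc(C(=O)N2CCC(n3cncc3-c3ccc(OS(=O)(=O)c4cccc5cnccc45)cc3)CC2)cc1` gives 109 nM

In an assay on HEK293 cells for antagonist activity at P2X purinoceptor 7 (Homo sapiens), read by fluorescence, with a stated time of 2 h (on this read-out higher numbers stand for weaker inhibition and lower numbers for stronger inhibition), compound 2 stands lowest of the three, beyond the scatter from both others. For the measured compounds named here, the one measured step, a 4.4-fold higher number from compound 2 to compound 3 (0.64 log units; beyond the scatter), concerns the amide aryl, not the sulfonate, and so does not bear on the present change.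

Compound 4 `CS(=O)(=O)c1ccc(C(=O)N2CCC(n3cncc3-c3ccc(OS(=O)(=O)c4cccc(C#N)c4)cc3)CC2)cc1` differs from compound 2 by 3-cyanophenyl in place of isoquinolin-5-yl on a sulfonyl sulfur. Compound 1 carries the same 3-cyanophenyl sulfonate but also a different amide, so its value alone cannot isolate the effect. Going by the values given here, with no direct precedent, a small shift toward weaker inhibition is expected for compound 4, around 45 nM (range 15 nM to 135 nM), i.e. an expected 1.8-fold higher number from compound 2 to compound 4 (0.26 log units; within the scatter).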

Compound 4, half-maximal inhibitory concentration: 143 nM
For compound 4 the middle estimate is 3.2-fold (0.50 log units) below the measured one; the measured number lies above the stated range.
By their numbers in this assay, from the lowest: compound 2; then compounds 1, 3 and 4 (each within the scatter of the next).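

In this assay the aryl group on the sulfonyl sulfur proves to matter: 3-cyanophenyl in place of isoquinolin-5-yl gives a 5.7-fold higher number from compound 2 to compound 4 (0.76 log units; beyond the scatter) with the amide unchanged. With 3-cyanophenyl held, the amide aryl exchange gives a 2.0-fold higher number from compound 1 to compound 4 (0.29 log units; within the scatter) and so does not separate 4-(methylsulfonyl)phenyl from 4-chloro-3-(trifluoromethyl)phenyl in this pair. No measurement at hand accounts for the sulfonate step.

Still open, going by these compounds, is whether that step follows the ring nitrogen or the second ring of isoquinolin-5-yl, and how naphthyl or a carboxylic acid-bearing phenyl would read on the sulfonyl sulfur.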